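The source may hold more compounds than are shown below. What is called first, only, known or untested is meant among the compounds shown, and "the series" means these compounds.

For the measured compounds named here, compound 2 `Cc1c(/N=C/c2ccccc2Cl)c(=O)n(-c2ccccc2)n1C` gives the highest of the two numbers so far in a functional assay on HT-29 cells (Homo sapiens) for cytotoxicity, read by MTT assay, with a stated time of 72 h (on this read-out lower numbers stand for stronger inhibition and higher numbers for weaker inhibition), at 309000000 nM; compound 1 `Cc1c(/N=C/c2cccc(O)c2)c(=O)n(-c2ccccc2)n1C` gives 166000000 nM, and the step of a 1.9-fold higher number from compound 1 to compound 2 (0.27 log units; within the scatter) lies within the scatter. Compound 3 `COc1ccccc1/C=N/c1c(C)n(C)n(-c2ccccc2)c1=O` differs from compound 2 by methoxy in place of chloro on an aromatic carbon. Going by the values given here, no measured step swaps these two groups; the only step at this aromatic ring, a 1.9-fold higher number from compound 1 to compound 2 (0.27 log units; within the scatter), stays within the scatter, so no step beyond the scatter is expected in this assay. Compound 3 is estimated at 250000000 nM, range 90000000 nM to 700000000 nM, the expected step being a 1.2-fold lower number from compound 2 to compound 3 (0.09 log units; within the scatter).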

Compound 3, half-maximal inhibitory concentration: 70800000 nM
For compound 3 the middle estimate is 3.5-fold (0.55 log units) above the measured one; measured number below the stated range.
By their numbers in this assay, from the lowest: compound 3; then compounds 1 and 2 (each within the scatter of the next).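

For the compounds shown here, on an aromatic carbon ortho to a large group, methoxy in place of chloro gives, with a 4.4-fold lower number from compound 2 to compound 3 (0.64 log units; beyond the scatter), the first step beyond the scatter in this assay, a modest one. Going from 3-hydroxyphenyl to 2-methoxyphenyl also clears the scatter, with a 2.3-fold lower number from compound 1 to compound 3 (0.37 log units; beyond the scatter), so changes on this ring can shift the number, which the earlier pair did not show. Nothing available explains this shift. Open, on these data alone, is how an amine, a carboxylic acid or a longer chain such as ethoxy would read at this position, and whether methoxy gives a similar step elsewhere on the ring.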